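Moving the chlorine on the aryl ring of a pyridine-free core

A few compounds are considered here, and "the series" means these few. Any claim that something is new, unique, unknown or untested is made for them only; others in the source may bear on it.

Compound 1 `Oc1cccc(-c2cc(-c3cccc(Cl)c3)nc(-c3ccco3)c2)c1`: 3570 nM
Compound 2 `Oc1cccc(-c2cc(-c3ccsc3)nc(-c3cccc(Cl)c3)c2)c1`: 3540 nM
Compound 3 `Oc1ccc(-c2cc(-c3cccc(Cl)c3)nc(-c3ccco3)c2)cc1`: 5220 nM

Of the compounds shown here, three have been measured in a functional assay on T47D cells (Homo sapiens) for cytotoxicity, read by CCK-8 assay and cell counting, with a stated time of 2 days; on this read-out lower numbers stand for stronger inhibition and higher numbers for weaker inhibition. In this assay compound 1 gives 3570 nM, which places it second highest of the three numbers, with compound 2 closest and compound 3 furthest away. Both measured steps out of compound 1 stay within the scatter: a 1.0-fold lower number from compound 1 to compound 2 (0.00 log units; within the scatter) and a 1.5-fold higher number from compound 1 to compound 3 (0.17 log units; within the scatter). Neither of them touches the chlorophenyl group.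

Compound 4 `Oc1cccc(-c2cc(-c3ccco3)nc(-c3ccccc3Cl)c2)c1` has the same atoms as compound 1, joined differently: 2-chlorophenyl in place of 3-chlorophenyl on an aromatic carbon. Going by the values given here, no measured step reports a change to this group, so nothing in the data speaks for a shift beyond the scatter in either direction. Because the two known steps from compound 1 are a 1.0-fold lower number from compound 1 to compound 2 (0.00 log units; within the scatter) and a 1.5-fold higher number from compound 1 to compound 3 (0.17 log units; within the scatter), the shared core appears tolerant of small aromatic changes in this assay. Compound 4 is therefore expected to land near compound 1, with a step of a 1.1-fold higher number from compound 1 to compound 4 (0.05 log units; within the scatter). The estimate for compound 4 is 4000 nM, within a range from 1500 nM to 11000 nM.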

Compound 4, half-maximal inhibitory concentration: 2010 nM
Compound 4: middle estimate off by 2.0-fold (0.30 log units), on the high side, within the range that was stated.
By their numbers in this assay, from the lowest: compounds 4, 2, 1 and 3 (each within the scatter of the next, the first and the last beyond it).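

Going by these compounds alone, the chlorophenyl group, untouched by the earlier steps, is now changed: in this assay, 2-chlorophenyl in place of 3-chlorophenyl, on the aromatic carbon next to the ring nitrogen, gives a 1.8-fold lower number from compound 1 to compound 4 (0.25 log units; within the scatter). The chlorine can therefore take either of these two places on this ring without a step beyond the scatter, at least with the 3-hydroxyphenyl and furan-2-yl groups kept as they are. No measurement is available that bears on this result.

The compounds shown leave open whether 4-chlorophenyl at this position would also stay within the scatter. They also do not say whether a ring carrying an amine or a carboxylic acid in place of the chlorine would give a number in the same region.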